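Hydroxy in place of fluoro on the aryl group

This account rests on a few compounds, and the source may have more. Where it says the series, first, only, none or still open, it means among the compounds named here.

Compound 2 (`O=C(Nc1ccc(F)c(-c2nc3ncc(-c4ccc(F)cc4)cc3[nH]2)c1)N1CCCC1`) has only a limit in an ADME assay on HepG2 cells (Homo sapiens) for cytotoxicity, read by resazurin assay, with a stated time of 48 h (a higher number here means that more compound is needed for the effect, a lower number that less compound is needed), and no number. Compound 2 gives > 50000 nM as a limit. Compound 1 (`O=C(Nc1ccc(F)c(-c2nc3ncc(-c4cc(F)ccc4F)cc3[nH]2)c1)N1CCCC1`) gives > 50000 nM as a limit too. Compound 3 (`Cc1nc(C)c(C(=O)Nc2ccc(F)c(-c3nc4ncc(-c5ccccc5Cl)cn4n3)c2)o1`) likewise gives > 50000 nM as a limit. The whole set thus comes down to the limit of > 50000 nM in this assay, at which 3 of the 3 values shown sit, and holds no measured number.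

Compound 4 (`O=C(Nc1ccc(F)c(-c2nc3ncc(-c4ccc(O)cc4)cc3[nH]2)c1)N1CCCC1`) comes from compound 2 by one change, 4-fluorophenyl to 4-hydroxyphenyl, with hydroxy in place of fluoro on an aromatic carbon. Within the data shown here, no measured step exchanges fluoro for hydroxy. Among the measured compounds shown here, the only measured step on this aryl group (a step that the two limits leave unreadable from compound 1 to compound 2) gives no size to carry over, so no step beyond the scatter is expected in this assay in either direction. The estimated move is a number no higher from compound 2 to compound 4 (the limit leaves the size open) and nothing firmer. For compound 4 the expected value is 50000 nM within an estimated range of 20000 nM to 100000 nM and another limit is the likeliest report.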

Compound 4, half-maximal effective concentration: > 50000 nM
Compound 4 gave a limit, no number; the forecaster's own chance of this, stated with the estimate: 75%; the middle value sits exactly at the limit.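

Compound 4 gives only a limit, as do compound 1 and compound 2, so the steps from compound 2 to compound 4 and from compound 1 to compound 4 cannot be read: the limit of > 50000 nM in this assay, at which 4 of the 4 values shown sit. The compounds shown leave open whether 4-fluorophenyl and 4-hydroxyphenyl differ at all in this assay.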